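A few compounds are considered here, and "the series" means these few. Any claim that something is new, unique, unknown or untested is made for them only; others in the source may bear on it.

In a toxicity assay on THP-1 cells (Homo sapiens) for inhibition (a higher number here means that more compound is tolerated, a lower number that less compound is tolerated), compound 1 `Cc1ccc(-c2cnc(NC(=O)c3ccc(F)cc3)n2C)cc1` gives 60000 nM. Compound 2 `Cn1c(-c2ccc(C#N)cc2)cnc1NC(=O)c1ccc(F)cc1` is reported only as a limit, > 50000 nM. Compound 3 `Cn1c(-c2cccc([N+](=O)[O-])c2)cnc1NC(=O)c1ccc(F)cc1` is also reported only as a limit, > 50000 nM. Compounds 2 and 3 thus share (the limit of > 50000 nM in this assay, at which 2 of the 3 values shown sit). Compound 4 `Cn1c(-c2cccc(F)c2)cnc1NC(=O)c1ccc(F)cc1` carries fluoro in place of nitro on an aromatic carbon, (fluoro in place of nitro on an aromatic carbon). Among the measured compounds shown here, the only measured step, a step that the limit leaves unreadable from compound 1 to compound 2, involves other groups and has no readable size, so it offers no size to carry over. For the measured compounds named here, with compound 1 at 60000 nM as the only number available, no change beyond the scatter is expected in this assay. The expected step is a step that the limit leaves unreadable from compound 3 to compound 4. For compound 4 the estimate is 55000 nM, with an expected range of 25000 nM to 100000 nM.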

Compound 4, half-maximal cytotoxic concentration: 58000 nM
Beside the measured number, compound 4's estimate is 1.1-fold (0.02 log units) below it, and the stated range covers the measured number.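

In this assay, among the compounds shown here, 3-fluorophenyl in place of 4-methylphenyl on an aromatic carbon gives a 1.0-fold lower number from compound 1 to compound 4 (0.01 log units; within the scatter), so this is the first readable step and it shows no change at this ring. Fluoro, meta to a large group, yields a number where nitro in compound 3 has only a limit. The steps to compound 4 from compound 2 and from compound 3 cannot be read, because each starts from a limit: the limit of > 50000 nM in this assay, at which 2 of the 4 values shown sit. The compounds shown leave open whether an amine or a carboxylic acid in this place would move the number beyond the scatter.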